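The source may hold more compounds than are shown below. What is called first, only, known or untested is meant among the compounds shown, and "the series" means these compounds.

Compound 1 `O=C(Nc1ccc(Oc2ccnc3[nH]ccc23)cc1)c1nn(-c2ccc(Cl)cc2)ccc1=O` gives 25100 nM in a functional assay on A549 cells (Homo sapiens) for cytotoxicity, read by MTT assay, with a stated time of 72 h; a lower number here means a stronger inhibitor, a higher number a weaker inhibitor. Compound 2 `O=C(Nc1ccc(Oc2ccnc3[nH]ccc23)cc1)c1nn(-c2ccc(Br)cc2)ccc1=O` gives 6240 nM in this assay, and compound 3 `O=C(Nc1ccc(Oc2ccnc3[nH]ccc23)cc1)c1nn(-c2ccc(Br)cc2F)ccc1=O` gives 26100 nM. Compound 3 carries the highest number of the three: compound 1 lies within the scatter of it, while compound 2 is set apart by a 4.2-fold higher number from compound 2 to compound 3 (0.62 log units; beyond the scatter). The next member, compound 4 `O=C(Nc1ccc(Oc2ccnc3[nH]ccc23)cc1)c1nn(-c2ccc(Cl)c(F)c2)ccc1=O`, differs from compound 3 by 4-chloro-3-fluorophenyl in place of 4-bromo-2-fluorophenyl on an aromatic nitrogen. Within the data shown here, two measured steps bear on this change. The halogen exchange has been seen once, as a 4.0-fold lower number from compound 1 to compound 2 (0.60 log units; beyond the scatter), so the return from bromo to chloro points toward a higher number. Among the measured compounds shown here, a fluoro has been seen once, as a 4.2-fold higher number from compound 2 to compound 3 (0.62 log units; beyond the scatter), but that fluoro belongs to 4-bromo-2-fluorophenyl, whereas compound 4 carries 4-chloro-3-fluorophenyl, and no measured pair shows that arrangement. Compound 4 is therefore expected to stay near compound 3 or to move to a somewhat higher number, an expected step of a 1.3-fold higher number from compound 3 to compound 4 (0.13 log units; within the scatter). The estimate for compound 4 is 35000 nM, with a range from 12000 nM to 100000 nM.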

Compound 4, half-maximal inhibitory concentration: 2580 nM
Compound 4: the middle estimate sits 14-fold (1.13 log units) above what was measured; the whole stated range lies above it.
By their numbers in this assay, from the lowest: compound 4; then compound 2; then compounds 1 and 3 (each within the scatter of the next).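

In this assay, a fluoro added to the phenyl group on the aromatic nitrogen has no single direction, as the two steps that add it disagree: the same change on two cores in this assay, a 4.2-fold higher number (0.62 log units; beyond the scatter) from compound 2 to compound 3 and a 9.7-fold lower number (0.99 log units; beyond the scatter) from compound 1 to compound 4, 41-fold (1.61 log units) apart, beyond the scatter of two such steps. The change to 4-chloro-3-fluorophenyl gives a 10-fold lower number from compound 3 to compound 4 (1.01 log units; beyond the scatter), a 9.7-fold lower number from compound 1 to compound 4 (0.99 log units; beyond the scatter) and a 2.4-fold lower number from compound 2 to compound 4 (0.38 log units; beyond the scatter). Among these compounds, compound 4 therefore holds the lowest number of the four, with each of its steps beyond the scatter, and this position proves more sensitive to the halogen and fluoro arrangement than the earlier compounds showed.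

No pair shown keeps the same halogen while the fluoro changes place, so the place of the fluoro cannot be separated from the identity of the halogen. From the compounds shown here alone, how a methoxy or a trifluoromethyl in place of the halogen on this phenyl group would read also remains open.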